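Series notes: from compound 3 to compound 4

The source may hold more compounds than are shown below. What is called first, only, known or untested is meant among the compounds shown, and "the series" means these compounds.

Going by the values given here, in a functional assay (trachea) for antagonist activity, with Cavia porcellus as the target (on this read-out lower numbers stand for lower potency and higher numbers for higher potency (the scale is a negative logarithm)), compound 3 `CCCCC(CC)C(=O)Nc1ccc2ccn(Cc3ccc(C(=O)NS(=O)(=O)c4ccccc4)cc3OC)c2c1` gives 8.6, the highest of the three numbers measured so far. In this assay compound 1 `CCCCC(CC)C(=O)Nc1ccc2ccn(Cc3ccc(C(=O)NS(=O)(=O)c4ccc(Cl)cc4)cc3OC)c2c1` gives 7.8, and compound 2 `CCCCC(CC)C(=O)Nc1ccc2ccn(Cc3ccc(C(=O)NS(=O)(=O)c4ccc(F)cc4)cc3OC)c2c1` gives 7.7. The steps of a number 0.80 log units higher from compound 1 to compound 3 (beyond the scatter) and a number 0.90 log units higher from compound 2 to compound 3 (beyond the scatter) both lie beyond the scatter, whereas a number 0.10 log units lower from compound 1 to compound 2 (within the scatter) does not. Compound 4 `CCCCC(CC)C(=O)Nc1ccc2ccn(Cc3ccc(C(=O)C(C#N)S(=O)(=O)c4ccccc4)cc3OC)c2c1` has not yet been measured in this assay. It differs from compound 3 in one place: cyano(phenylsulfonyl)methyl in place of (phenylsulfonyl)amino on a carbonyl carbon. Every measured step in the set concerns chloro, fluoro or hydrogen on an aromatic carbon, so none of them bears on exchanging (phenylsulfonyl)amino for cyano(phenylsulfonyl)methyl on the carbonyl carbon; the size and direction of that step are not anchored by any measured pair, and the hydrogen-bond donor count falls to zero while the acceptor count rises. A step of a number 1.10 log units lower from compound 3 to compound 4 (beyond the scatter) is expected, with wide uncertainty on either side. For compound 4 the estimate in this assay is 7.5, between 6.5 and 8.6.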

Compound 4, negative logarithm of the antagonist equilibrium constant: 8.1
Beside the measured number, compound 4's estimate is 0.60 log units below it; the measured number falls inside the stated range.
By their numbers in this assay, from the lowest: compounds 2, 1 and 4 (each within the scatter of the next, the first and the last beyond it); then compound 3.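

In this assay, the carbonyl carbon keeps a high number when (phenylsulfonyl)amino, with 1 hydrogen-bond donor, gives way to cyano(phenylsulfonyl)methyl, with 0 hydrogen-bond donors: the exchange gives a number 0.50 log units lower from compound 3 to compound 4 (beyond the scatter), a modest loss, so that donor is not needed for a number in this range. Set against the compounds with a halogen on the phenyl ring, the exchange gives a number 0.40 log units higher from compound 2 to compound 4 (beyond the scatter) and a number 0.30 log units higher from compound 1 to compound 4 (within the scatter), which places compound 4 within the range those compounds span or just past it. No measurement on hand accounts for the size of this step.

Still open, from the compounds shown here alone, is how a carboxylic acid on the carbonyl carbon would read in this assay. Also open, going by these compounds, is whether chloro or fluoro on the phenyl ring of cyano(phenylsulfonyl)methyl would lower the number as they do with (phenylsulfonyl)amino.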